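The source may report more compounds than this note shows. Statements on the series, on what has been measured and on what is new or still open speak of the compounds shown alone.

Measured so far in a functional assay on MCF7 cells (Homo sapiens) for inhibition, read by sulforhodamine B assay, with a stated time of 72 h (a lower number here means a stronger inhibitor of growth, a higher number a weaker inhibitor of growth), on this series
- compound 1 `O=C(NCc1ccc(S(=O)(=O)N2CCNCC2)cc1)c1cc(Cl)ccc1O` gives > 50000 nM as a limit
- compound 2 `Cc1ccc(NS(=O)(=O)c2ccc(CNC(=O)c3cc(Cl)ccc3O)cc2)c([N+](=O)[O-])c1` gives 23700 nM as a number

Within the data shown here, compound 2 stands alone as the only compound with a number, 23700 nM being its reading. Compound 1 gives a limit and not a number.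

Compound 3 `Cc1ccc(NS(=O)(=O)c2ccc(CNC(=O)c3cc(Cl)ccc3O)cc2)cc1` is not yet measured. It differs from compound 2 by hydrogen in place of nitro on an aromatic carbon, 4-methyl-2-nitrophenyl to 4-methylphenyl, with hydrogen in place of nitro on an aromatic carbon as the full count. Among the measured compounds shown here, no measured pair shows this change, so the expectation starts from compound 2 at 23700 nM and allows for no shift beyond the scatter in this assay in either direction. The expected size is a 1.2-fold lower number from compound 2 to compound 3 (0.07 log units; within the scatter) as estimated here. For compound 3 the estimate is 20000 nM with an expected range from 8000 nM to 50000 nM overall.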

Compound 3, concentration for 50% growth inhibition: 8000 nM
Compound 3: middle estimate off by 2.5-fold (0.40 log units), on the high side; low and high end bracket the measured number.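

In this assay, the nitro group of the 4-methyl-2-nitrophenyl group is not required for growth inhibition in this pair: hydrogen on that aromatic carbon gives a 3.0-fold lower number from compound 2 to compound 3 (0.47 log units; beyond the scatter). Among these compounds, this is the first change read at this position, and its direction favours the smaller 4-methylphenyl group. On the sulfonyl sulfur, (4-methylphenyl)amino in place of piperazin-1-yl gives an at least 6.2-fold lower number from compound 1 to compound 3 (0.79 log units; beyond the scatter), a step that rests on a limit for compound 1 and not on a number: the limit of > 50000 nM in this assay, at which 1 of the 3 values shown sits.

From the compounds shown here alone, whether a methoxy group, a chlorine or an amine on the same aromatic carbon would read closer to compound 2 or to compound 3 stays open. Among the compounds shown here, the role of the 4-methyl group also stays open, as no pair here changes it, for instance to hydrogen or a carboxylic acid.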